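A few compounds are considered here, and "the series" means these few. Any claim that something is new, unique, unknown or untested is made for them only; others in the source may bear on it.

In a functional assay on Caco-2 cells (Homo sapiens) for antiproliferative activity, read by MTT assay, with a stated time of 48 h (a higher number here means a weaker inhibitor, a lower number a stronger inhibitor), compound 1 `CCn1c(C(=O)NCCCN(C)C)ccc1C(CC)(CC)c1ccc(OCCC(O)(CC)CC)c(C)c1` gives 490 nM.
Compound 2 `CCn1c(C(=O)Nc2ccc(OC(F)(F)F)cc2)ccc1C(CC)(CC)c1ccc(OCCC(O)(CC)CC)c(C)c1` reaches only a limit in this assay, > 50000 nM.
Compound 3 `CCn1c(C(=O)NC(C)C(=O)O)ccc1C(CC)(CC)c1ccc(OCCC(O)(CC)CC)c(C)c1` gives 46500 nM in this assay.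

Compound 1 therefore has the lowest number shown; compound 3 is nearest, with a 95-fold higher number from compound 1 to compound 3 (1.98 log units; beyond the scatter), and compound 2 sits at the limit of > 50000 nM in this assay, at which 1 of the 3 values shown sits. Compound 4 `CCn1c(C(=O)N(C)CCO)ccc1C(CC)(CC)c1ccc(OCCC(O)(CC)CC)c(C)c1` differs from compound 1 by (2-hydroxyethyl)(methyl)amino in place of (3-(dimethylamino)propyl)amino on a carbonyl carbon. Going by the values given here, both measured steps that bear on this place, an at least 100-fold higher number from compound 1 to compound 2 (2.00 log units; beyond the scatter) and a 95-fold higher number from compound 1 to compound 3 (1.98 log units; beyond the scatter), removed the 3-(dimethylamino)propyl group and were large increases, so a large increase is expected here too, though (2-hydroxyethyl)(methyl)amino has no measured counterpart among compounds 2 and 3. Compound 4 is estimated at 15000 nM, between 3000 nM and 50000 nM, an expected 31-fold higher number from compound 1 to compound 4 (1.49 log units; beyond the scatter).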

Compound 4, half-maximal inhibitory concentration: 74 nM
Beside the measured number, compound 4's estimate is 200-fold (2.31 log units) above it, outside the stated range (below it).
By their numbers in this assay, from the lowest: compound 4; then compound 1; then compound 3. At a limit, above all of these: compound 2.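

In this assay, losing the 3-(dimethylamino)propyl group at this carbonyl carbon does not itself cost activity, since (2-hydroxyethyl)(methyl)amino gives a 6.6-fold lower number from compound 1 to compound 4 (0.82 log units; beyond the scatter). The amide substituent alone therefore separates a 630-fold lower number from compound 3 to compound 4 (2.80 log units; beyond the scatter) and an at least 670-fold lower number from compound 2 to compound 4 (2.82 log units; beyond the scatter), so the earlier large rises cannot be read as a loss of that group alone. The value of compound 2 is a limit, not a number: the limit of > 50000 nM in this assay, at which 1 of the 4 values shown sits.

On these data alone, the change swaps the chain and adds a methyl on the amide nitrogen at once, so which part matters stays open. A plain 2-hydroxyethyl amide, a 2-methoxyethyl chain or a morpholine amide would separate these.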